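Aminopyrimidine in place of aminothiophene on the ketone

A few compounds are considered here, and "the series" means these few. Any claim that something is new, unique, unknown or untested is made for them only; others in the source may bear on it.

Two compounds sharing the core of compound 1 `COc1ccc(-c2cc3ccccc3nc2/C=C/C(=O)c2c(OC)cccc2OC)cc1` have been measured in a functional assay on NCI-H460 cells (Homo sapiens) for antiproliferative activity, read by XTT assay, with a stated time of 72 h; a higher number here means a weaker inhibitor, a lower number a stronger inhibitor. In this assay compound 1 gives 6630 nM. Compound 2 `COc1ccc(-c2cc3ccccc3nc2/C=C/C(=O)c2sccc2N)cc1` carries a 3-aminothiophen-2-yl group on the carbonyl carbon in place of the 2,6-dimethoxyphenyl group of compound 1. In this assay compound 2 reaches only the limit of the assay, > 10000 nM, so for compound 2 a limit and no number is known. Among the measured compounds shown here, the single measured step at this carbonyl position is an at least 1.5-fold higher number from compound 1 to compound 2 (0.17 log units; that floor lies within the scatter), and it rests on (the limit of > 10000 nM in this assay, at which 1 of the 2 values shown sits).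

Compound 3 `COc1ccc(-c2cc3ccccc3nc2/C=C/C(=O)c2cnc(N)nc2C)cc1` differs from compound 2 by 2-amino-4-methylpyrimidin-5-yl in place of 3-aminothiophen-2-yl on a carbonyl carbon. For the measured compounds named here, no measured step covers the 2-amino-4-methylpyrimidin-5-yl group, and the one step at this position gives only a floor, so the direction of the change from compound 2 to compound 3 cannot be read from the data. The expectation for compound 3 is a step that the limit leaves unreadable from compound 2 to compound 3, close to no change. Compound 3 is accordingly estimated at 12000 nM, in a range from 3000 nM to 40000 nM, with a further limit rather than a number judged about as likely as not.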

Compound 3, half-maximal inhibitory concentration: > 10000 nM
Compound 3 ended at the assay's limit; the forecaster's own chance of this, stated with the estimate: 55%; the middle value lies beyond the limit too.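

In this assay, compound 3 shows that a six-membered aromatic ring on the carbonyl carbon, the 2-amino-4-methylpyrimidin-5-yl group, also gives a limit and no number, as the five-membered 3-aminothiophen-2-yl group did. Replacing the 2,6-dimethoxyphenyl group with the 2-amino-4-methylpyrimidin-5-yl group gives an at least 1.5-fold higher number from compound 1 to compound 3 (0.17 log units; that floor lies within the scatter), so this floor does not establish a loss relative to compound 1. The step between compound 2 and compound 3 cannot be read, and the picture at this position still rests mainly on a limit: the limit of > 10000 nM in this assay, at which 2 of the 3 values shown sit.

From the compounds shown here alone, how far compound 2 and compound 3 actually lie beyond the limit stays open, as does whether either amino-bearing ring differs from the 2,6-dimethoxyphenyl group by more than the scatter. Also open, going by these compounds, is what a plain phenyl group, or a pyrimidin-5-yl group without the amine and the methyl, would give on the same carbonyl carbon.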